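A few compounds are considered here, and "the series" means these few. Any claim that something is new, unique, unknown or untested is made for them only; others in the source may bear on it.

In a functional assay on MCF7 cells (Homo sapiens) for cytotoxicity, read by MTT assay, with a stated time of 6 days (on this read-out lower numbers stand for an effect already at smaller amounts and higher numbers for an effect only at larger amounts of compound), two compounds have been measured so far. Compound 1 `Nc1ccc(-c2cc(=O)c3cc(O)ccc3o2)cc1` gives > 25 ug/mL, which is a limit of the assay and not a number. Among the measured compounds shown here, compound 2 `CC(=O)Nc1ccc(-c2cc(=O)c3c(OC(C)=O)cc(OC(C)=O)cc3o2)cc1` gives 1.78 ug/mL, the only actual number, so it is the sole numerical reference point. Compound 3 `CC(=O)Nc1ccc(-c2cc(=O)c3ccc(OC(C)=O)cc3o2)cc1` departs from compound 2 in one place: hydrogen in place of acetoxy on an aromatic carbon. Hydrogen stands in place of acetoxy on an aromatic carbon, and the rest of the structure is unchanged. For the measured compounds named here, no measured pair in this assay isolates this change, so its size can only be judged loosely, starting from compound 2 at 1.78 ug/mL. A moderate shift towards larger amounts, somewhat beyond the usual scatter, is expected, with a 2.8-fold higher number from compound 2 to compound 3 (0.45 log units; beyond the scatter) as the estimated step. For compound 3 the estimated value is 5 ug/mL, with an expected range from 1.5 ug/mL to 20 ug/mL.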

Compound 3, concentration for half-maximal effect: 19.2 ug/mL
Beside the measured number, compound 3's estimate is 3.8-fold (0.58 log units) below it; measured number inside the range.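

In this assay, among the compounds shown here, this is the first measured step, and it is large: putting hydrogen in place of acetoxy on an aromatic carbon meta to an acetoxy group gives an 11-fold higher number from compound 2 to compound 3 (1.03 log units; beyond the scatter). This position is therefore not indifferent to what it carries, and the acetoxy group left in compound 3 does not make up for the one that leaves. Compound 3 now lies towards the upper end of the values read here, where the only other entry is a limit of the assay and not a number: the limit of > 25 ug/mL in this assay, at which 1 of the 3 values shown sits.

On these data alone, whether this position needs acetoxy itself, or would accept another group such as methoxy or an amine, stays open. No pair shown changes the remaining acetoxy group of compound 3 alone, so its share stays open too.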